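The source may hold more compounds than are shown below. What is called first, only, known or untested is meant among the compounds shown, and "the series" means these compounds.

Within the data shown here, in a physicochemical assay for solubility, read by spectrophotometry, in phosphate buffer, with a stated time of 2 h, at pH 7.4 (on this read-out lower numbers stand for lower solubility and higher numbers for higher solubility), compound 3 (`COc1ccc2[nH]c(C(=O)N3CC(=O)N(Cc4ccccc4)[C@@H](COCc4ccccc4)C3)cc2c1`) gives 8800 nM as the lowest number so far. Compound 2 (`COc1ccc2[nH]c(C(=O)N3CC(=O)N(Cc4ccccc4)[C@@H](CN4CCC5(CC4)CC5)C3)cc2c1`) gives 28200 nM in the same read-out. Compound 1 (`COc1ccc2[nH]c(C(=O)N3CC(=O)N(Cc4ccccc4)[C@@H](CN4CCCCC4)C3)cc2c1`) shows > 25000 nM as a limit of the assay and not a number. Compound 4 (`COc1ccc2[nH]c(C(=O)N3CC(=O)N(Cc4ccccc4)[C@@H](CN4CCC(C)CC4)C3)cc2c1`) is not yet measured and carries 4-methylpiperidin-1-yl in place of benzyloxy (4-methylpiperidin-1-yl in place of benzyloxy on a saturated chain carbon bound to a saturated ring carbon). The measured steps that bear on this run the opposite way, with an at least 2.8-fold lower number from compound 1 to compound 3 (0.45 log units; beyond the scatter) and a 3.2-fold lower number from compound 2 to compound 3 (0.51 log units; beyond the scatter) both ending at benzyloxy. The remaining step, a step that the limit leaves unreadable from compound 1 to compound 2 gives no size. A step of like size towards a higher number is therefore expected in this assay and the estimated step is a 3.2-fold higher number from compound 3 to compound 4 (0.50 log units; beyond the scatter) on this basis. For compound 4 the estimated value is 28000 nM with 14000 nM to 55000 nM as its expected range.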

Compound 4, solubility: 93100 nM
Beside the measured number, compound 4's estimate is 3.3-fold (0.52 log units) below it; the whole stated range lies below it.
By their numbers in this assay, from the lowest: compound 3; then compound 2; then compound 4.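

In this assay, among these compounds, the exchange at this position now reaches an 11-fold higher number from compound 3 to compound 4 (1.02 log units; beyond the scatter), the widest readable step so far. Even with the six-membered ring with its nitrogen kept, altering that ring's substitution alone gives a 3.3-fold higher number from compound 2 to compound 4 (0.52 log units; beyond the scatter), so the number moves beyond the scatter within the saturated amines too. Compound 1 gives a limit and not a number, so its step to compound 4 cannot be read: the limit of > 25000 nM in this assay, at which 1 of the 4 values shown sits.

From the compounds shown here alone, what the added methyl contributes on its own therefore stays open. Also open, going by these compounds, is how a morpholin-4-yl group or a carboxylic acid on the same saturated chain carbon would read.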